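The source may report more compounds than this note shows. Statements on the series, on what has been measured and on what is new or still open speak of the compounds shown alone.

Working notes on the series, read in a functional assay on MCF7 cells (Homo sapiens) for cytotoxicity, read by MTT assay, with a stated time of 72 h; on this read-out higher numbers stand for weaker inhibition and lower numbers for stronger inhibition. Compound 1 `COc1cccc(/C=C2\CCC/C(=C\c3cccc(Cl)c3)C2=O)c1OC` gives 12000 nM, and compound 2 `COc1cccc(/C=C2\CCC/C(=C\c3ccc(Br)cc3)C2=O)c1OC` gives 13800 nM. With only these two values measured, compound 2 stands level with compound 1 within the scatter, and the pair cannot be ranked.

The next compound is compound 3 `COc1ccccc1/C=C1\CCC/C(=C\c2cccc(OC)c2OC)C1=O`. Its difference from compound 2 is 2-methoxyphenyl in place of 4-bromophenyl on a double-bonded chain carbon bound to a double-bonded ring carbon.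

For the measured compounds named here, the only measured step at this place is a 1.2-fold higher number from compound 1 to compound 2 (0.06 log units; within the scatter). It exchanges 3-chlorophenyl for 4-bromophenyl and stays within the scatter. Going by the values given here, no measured compound carries 2-methoxyphenyl at this place, so that single step is weak guidance for the new group. On this evidence, no step beyond the scatter is expected in this assay, and no direction can be assigned. The expected change is a 1.3-fold lower number from compound 2 to compound 3 (0.10 log units; within the scatter), which is an estimate with wide uncertainty. Compound 3 is estimated at 11000 nM, with an expected range of 4000 nM to 25000 nM.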

Compound 3, half-maximal inhibitory concentration: 12000 nM
Compound 3: the middle estimate sits 1.1-fold (0.04 log units) below what was measured; the range from low to high includes it.
By their numbers in this assay, from the lowest: compounds 1, 3 and 2 (each within the scatter of the next).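

In this assay, 2-methoxyphenyl in place of 4-bromophenyl gives a 1.2-fold lower number from compound 2 to compound 3 (0.06 log units; within the scatter) at this place, and 2-methoxyphenyl in place of 3-chlorophenyl gives no change at the digits printed from compound 1 to compound 3 (within the scatter) on the same shared core. The earlier pair showed only an exchange between a chlorine-bearing and a bromine-bearing phenyl group, whereas compound 3 extends the comparison to a group with no halogen, 8 heavy atoms and 1 hydrogen-bond acceptor, and the printed steps still stay within the scatter. So, across these three compounds, replacing either halogen-bearing phenyl group with 2-methoxyphenyl on a double-bonded chain carbon bound to a double-bonded ring carbon opens no measurable gap, and no measurement at hand offers an explanation for that.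

All three groups at this place are substituted phenyl groups, so the compounds shown leave open whether the same level holds for a group of another kind, such as a carboxylic acid or a simple amine on a longer chain. They also leave open whether this lack of separation extends beyond the MCF7 read-out of this assay to any other measurement.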